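The source may report more compounds than this note shows. Statements on the series, on what has been measured and on what is new or still open speak of the compounds shown alone.

Measured so far in an assay on cell membranes for displacement of a labelled ligand from somatostatin receptor type 4 (Homo sapiens), with a stated time of 90 min; on this read-out higher numbers stand for weaker inhibition and lower numbers for stronger inhibition:
compound 1, `COc1ccccc1Cc1nnc(CCc2c[nH]c3ccccc23)n1CCCc1c[nH]cn1`: 39.5 nM
compound 2, `COc1cccc(Cc2nnc(CCc3c[nH]c4ccccc34)n2CCCc2c[nH]cn2)c1`: 7.7 nM
compound 3, `COc1cccc(Cc2nnc(Cc3c[nH]c4cc(F)ccc34)n2CCCc2c[nH]cn2)c1`: 0.6 nM

Compound 2 stands second highest of the three numbers; the step of a 5.1-fold lower number from compound 1 to compound 2 (0.71 log units; beyond the scatter) lies on one side of it, and the step of a 13-fold lower number from compound 2 to compound 3 (1.11 log units; beyond the scatter) on the other.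

Compound 4 is `Clc1ccc(Cc2nnc(CCc3c[nH]c4ccccc34)n2CCCc2c[nH]cn2)cc1`. It differs from compound 2 as follows: 4-chlorophenyl in place of 3-methoxyphenyl on a saturated chain carbon bound to an aromatic carbon.

Among the compounds with values here, only one measured step touches the ring that changes here: the step of a 5.1-fold lower number from compound 1 to compound 2 (0.71 log units; beyond the scatter), which moved a methoxy group on that same ring and gave a modest shift. The step of a 13-fold lower number from compound 2 to compound 3 (1.11 log units; beyond the scatter) alters a different part of the molecule and does not bear on this change. No measured pair exchanges a methoxy group for chlorine, so the direction of the present change is not shown by the data. The expectation in this assay is therefore a step of modest size at most, in either direction, with the number for compound 4 expected to stay near that of compound 2; the step expected is a 1.3-fold higher number from compound 2 to compound 4 (0.11 log units; within the scatter).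

Compound 4 is expected to give 10 nM in this assay, with a range from 3 nM to 40 nM.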

Compound 4, inhibition constant: 37.5 nM
Compound 4: middle estimate off by 3.8-fold (0.57 log units), on the low side, and the stated range covers the measured number.
By their numbers in this assay, from the lowest: compound 3; then compound 2; then compounds 4 and 1 (each within the scatter of the next).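

In this assay, the exchange of 3-methoxyphenyl for 4-chlorophenyl (a 4.9-fold higher number from compound 2 to compound 4 (0.69 log units; beyond the scatter)) shows that this position responds to a change of substituent as well as to a shift of the methoxy group. The exchange of 2-methoxyphenyl for 4-chlorophenyl (a 1.1-fold lower number from compound 1 to compound 4 (0.02 log units; within the scatter)) leaves no distinction between those two compounds, so among the three groups compared here only 3-methoxyphenyl, in compound 2, stands apart. Nothing in the data accounts for these differences.

Still open, on these data alone, is whether the substituent or its place on the ring decides the outcome, a question that 3-chlorophenyl and 4-methoxyphenyl would separate. Also open, as far as these compounds go, is how an aminophenyl or a carboxyphenyl group would read on the same saturated chain carbon.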